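Hydroxy to halogen on the pendant phenyl ring

The compounds below may be only part of what the source reports. "The series", "measured", "known", "first", "only" and "open" are said of these compounds alone.

Measured so far:
compound 1 `O=C1OC[C@H](Cc2ccccc2)[C@H]1Cc1ccccc1O` — 83000 nM
compound 2 `O=C1OC[C@H](Cc2ccccc2)[C@H]1Cc1ccccc1F` — 72000 nM

In a functional assay on HL-60 cells (Homo sapiens) for cytotoxicity, read by WST assay, with a stated time of 48 h (a lower number here means that less compound is needed, a higher number that more compound is needed for the effect), compound 1 gives 83000 nM, the highest of the two numbers shown. Compound 2 gives 72000 nM, a step of a 1.2-fold lower number from compound 1 to compound 2 (0.06 log units; within the scatter). Compound 3 `O=C1OC[C@H](Cc2ccccc2)[C@H]1Cc1ccccc1Cl` differs from compound 1 by chloro in place of hydroxy on an aromatic carbon. For the measured compounds named here, only the step from compound 1 to compound 2 bears on this change, and it stayed within the scatter; so for this assay no step beyond the scatter is expected, at most a slightly lower number. For compound 3 the estimate is 70000 nM, range 35000 nM to 140000 nM, an expected step of a 1.2-fold lower number from compound 1 to compound 3 (0.07 log units; within the scatter).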

Compound 3, half-maximal effective concentration: 37000 nM
Compound 3: middle estimate off by 1.9-fold (0.28 log units), on the high side, and the stated range covers the measured number.
By their numbers in this assay, from the lowest: compounds 3, 2 and 1 (each within the scatter of the next, the first and the last beyond it).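

In this assay, for the compounds shown here, chloro in place of hydroxy, on the aromatic carbon ortho to a large group, gives the first step beyond the scatter at this position (a 2.2-fold lower number from compound 1 to compound 3 (0.35 log units; beyond the scatter)), though a modest one, which fluoro in place of hydroxy did not give. Chloro in place of fluoro stays within the scatter (a 1.9-fold lower number from compound 2 to compound 3 (0.29 log units; within the scatter)), so the two halogens are not separated here. No measurement bears on the reason for the step. From the compounds shown here alone, how bromo, methoxy or an amine at this place would compare with chloro stays open. Going by these compounds, whether the step carries over to other places on the ring also stays open.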